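The source may report more compounds than this note shows. Statements on the series, on what has been measured and on what is new or still open speak of the compounds shown alone.

Of the compounds shown here, two have been measured so far. In a physicochemical assay for lipophilicity, at pH 7.4 (on this read-out higher numbers stand for higher lipophilicity and lower numbers for lower lipophilicity), compound 1 `Cc1cc(C(=O)O)nn1Cc1cc(Br)ccc1OCc1ccccc1` gives 1.2 and compound 2 `Cc1cc(C(=O)NN2CCCCC2)nn1Cc1cc(Cl)ccc1OCC(C)C` gives 3.3, the higher of the two numbers, with the gap beyond the scatter. Going by the values given here, these two differ in more than one place, so no single-place step is available as a guide.

Compound 3 `Cc1cc(NC(=O)OC(C)(C)C)nn1Cc1cc(Cl)ccc1OCC(C)C` departs from compound 2 in one place: (tert-butoxycarbonyl)amino in place of (piperidin-1-yl)carbamoyl on an aromatic carbon. Here (tert-butoxycarbonyl)amino stands in place of (piperidin-1-yl)carbamoyl on an aromatic carbon, and the entering group has no ring. Among the compounds with values here, no measured step covers this swap, so any expectation is rough. A modest rise in this assay, somewhat beyond the scatter, is expected: the estimated change is a number 0.60 log units higher from compound 2 to compound 3 (beyond the scatter). For compound 3 the estimated value is 3.9, with an expected range of 3.3 to 4.5.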

Compound 3, distribution coefficient: > 3.7
Compound 3 was reported as a limit; the forecaster's own chance of this, stated with the estimate: 5%; the middle value lies beyond the limit too.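

Compound 3 is reported in this assay as a limit, > 3.7, and not as a number. Placing (tert-butoxycarbonyl)amino in place of (piperidin-1-yl)carbamoyl on this aromatic carbon gives the first single-place step in the series, a number at least 0.40 log units higher from compound 2 to compound 3 (beyond the scatter), so this position can change the read-out even when the entering group has no ring and the counted hydrogen-bond donors and acceptors stay the same. The step has only a lower bound because the reading for compound 3 sits at the limit: the limit of > 3.7 in this assay, at which 1 of the 3 values shown sits.

From the compounds shown here alone, how far compound 3 lies past its limit remains open, so the full size of this step is unknown. Also open, going by these compounds, is how this position responds to an amine or a methyl ester with the rest of compound 2 unchanged.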